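The source may report more compounds than this note shows. Statements on the series, on what has been measured and on what is new or still open speak of the compounds shown alone.

Series notes. The shared core is kept throughout; the measured compounds differ only in the group on the carbonyl carbon of the amide. Compound 1 `C=CC(=O)Nc1cccc(-c2nc3ccccc3s2)c1` carries vinyl there, compound 2 `O=C(O)/C=C/C(=O)Nc1cccc(-c2nc3ccccc3s2)c1` carries 2-carboxyethenyl, and compound 3 `CC(Cl)C(=O)Nc1cccc(-c2nc3ccccc3s2)c1` carries 1-chloroethyl. In an ADME assay on Raji cells (Homo sapiens) for inhibition, with a stated time of 72 h (on this read-out higher numbers stand for an effect only at larger amounts of compound and lower numbers for an effect already at smaller amounts), compound 1 gives > 25000 nM, which is a limit of the assay and not a number. In this assay compound 2 gives > 25000 nM, likewise a limit. In this assay compound 3 gives > 25000 nM, again a limit. Compound 2 thus stands at the common limit, as the limit of > 25000 nM in this assay, at which 3 of the 3 values shown sit, records, and the steps a step that the two limits leave unreadable from compound 1 to compound 2, a step that the two limits leave unreadable from compound 1 to compound 3 and a step that the two limits leave unreadable from compound 2 to compound 3 give no size.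

Compound 4 `O=C(Nc1cccc(-c2nc3ccccc3s2)c1)c1cnccc1Cl` is not yet measured. Its change from compound 2: 4-chloropyridin-3-yl in place of 2-carboxyethenyl on a carbonyl carbon. Within the data shown here, no measured step bears on this change; the three limits offer neither a size nor a direction, only the fact that every measured member sits at the limit. Compound 4 is therefore expected to give 25000 nM in this assay, within 6000 nM to 100000 nM. This estimate means a step of a number no higher from compound 2 to compound 4 (the limit leaves the size open), expected to be none beyond the scatter.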

Compound 4, half-maximal effective concentration: 12000 nM
For compound 4 the middle estimate is 2.1-fold (0.32 log units) above the measured one; the measured number falls inside the stated range.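

In this assay the group on the carbonyl carbon turns out to matter, as the change to 4-chloropyridin-3-yl gives an at least 2.0-fold lower number from compound 2 to compound 4 (0.31 log units; beyond the scatter), and the same holds against the other two groups, with an at least 2.0-fold lower number from compound 3 to compound 4 (0.31 log units; beyond the scatter) and an at least 2.0-fold lower number from compound 1 to compound 4 (0.31 log units; beyond the scatter). Among the groups shown, only this one, which brings an aromatic ring, gives a readable value, while vinyl, 2-carboxyethenyl and 1-chloroethyl, none with a ring, do not. Each of these sizes is only a lower bound because compound 1, compound 2 and compound 3 sit at a shared assay limit: the limit of > 25000 nM in this assay, at which 3 of the 4 values shown sit.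

The steps among compound 1, compound 2 and compound 3 cannot be read, and compound 4 alone cannot separate the share of the ring, its nitrogen and its chlorine. On these data alone, whether phenyl or an unsubstituted pyridin-3-yl in this place would give a similar value remains open.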